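This account rests on a few compounds, and the source may have more. Where it says the series, first, only, none or still open, it means among the compounds named here.

In an ADME assay on HUVEC cells (Homo sapiens) for inhibition, read by MTT assay, with a stated time of 48 h (on this read-out higher numbers stand for weaker inhibition and lower numbers for stronger inhibition), three compounds have been measured, and every one of them gives only a limit rather than a number. Compound 1 `COc1ccccc1-c1csc(N/N=C/c2ccc(F)c(F)c2)n1` gives a limit of > 100000 nM. Compound 2 `Fc1ccc(/C=N/Nc2nc(-c3ccccc3)cs2)cc1F` likewise gives a limit of > 100000 nM. Compound 3 `COc1cc(/C=N/Nc2nc(-c3ccccc3)cs2)cc(Br)c1OC` also gives a limit of > 100000 nM. Compound 2 and compound 1 differ in one place, (methoxy in place of hydrogen on an aromatic carbon), and the step that the two limits leave unreadable from compound 2 to compound 1 therefore has no readable size. How compound 3 differs from compound 2 is not broken down here.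

Compound 4 `COc1ccccc1-c1csc(N/N=C/c2cc(Br)c(OC)c(OC)c2)n1` has not yet been measured. It differs from compound 3 by methoxy in place of hydrogen on an aromatic carbon, the same change that leads from compound 2 to compound 1, at the same place. Since nothing more is known of that change than an unreadable step, the expectation for compound 4 rests on (the limit of > 100000 nM in this assay, at which 3 of the 3 values shown sit). The step that the estimate means, a step that the limit leaves unreadable from compound 3 to compound 4, is expected to be small. Compound 4 is accordingly expected to give about 150000 nM, within a range from 50000 nM to 500000 nM, and most probably again only as a limit.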

Compound 4, half-maximal inhibitory concentration: > 100000 nM
Compound 4: only a limit was reported (the forecaster's own chance of this, stated with the estimate: 85%); the middle value does not contradict the limit.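

Compound 3 and compound 4 each give only a limit, so the step between them cannot be read, and the methoxy change again has no readable size. The compounds shown leave open what number any of them would reach in this assay, and whether that change has any effect there, as all rest on one limit: the limit of > 100000 nM in this assay, at which 4 of the 4 values shown sit.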